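Series notes: 2,4-dimethoxyphenyl for 4-fluorophenyl on the alkene

The compounds below may be only part of what the source reports. "The series", "measured", "known", "first", "only" and "open" are said of these compounds alone.

Measured so far:
compound 1 `O=C(/C(=C\c1ccc(F)cc1)S(=O)(=O)c1ccc(Br)cc1)c1ccc(Br)cc1` — 4000 nM
compound 2 `O=C(/C(=C\c1ccc(O)c([N+](=O)[O-])c1)SCc1ccccc1Cl)c1ccc(Cl)cc1` — 10000 nM

In a functional assay on DU-145 cells (Homo sapiens) for inhibition, read by trypan blue exclusion, with a stated time of 96 h (on this read-out lower numbers stand for stronger inhibition of growth and higher numbers for weaker inhibition of growth), compound 1 gives the lower of the two numbers; compound 2 stands higher, beyond the usual scatter. For the measured compounds named here, no pair among the measured compounds differs in a single place, so no measured step is available.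

Compound 3 `COc1ccc(/C=C(\C(=O)c2ccc(Br)cc2)S(=O)(=O)c2ccc(Br)cc2)c(OC)c1` differs from compound 1 by 2,4-dimethoxyphenyl in place of 4-fluorophenyl on a double-bonded chain carbon bound to a double-bonded chain carbon. Going by the values given here, with no comparable step measured, the expected step is small: none beyond the scatter, in either direction.

Compound 3 is therefore expected near 3500 nM, with a range of 1200 nM to 10000 nM, that is an expected step of a 1.1-fold lower number from compound 1 to compound 3 (0.06 log units; within the scatter).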

Compound 3, concentration for 50% growth inhibition: 8000 nM
Compound 3: middle estimate off by 2.3-fold (0.36 log units), on the low side, within the range that was stated.
By their numbers in this assay, from the lowest: compounds 1, 3 and 2 (each within the scatter of the next, the first and the last beyond it).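

For the compounds shown here, the only single-place step sits on a double-bonded chain carbon bound to a double-bonded chain carbon: in this assay, 2,4-dimethoxyphenyl in place of 4-fluorophenyl gives a 2.0-fold higher number from compound 1 to compound 3 (0.30 log units; within the scatter), so this position accepts the exchange with no change beyond the scatter. No available data explain this result. Open, from the compounds shown here alone, is whether 4-methoxyphenyl, or a phenyl ring carrying a dimethylamino group or a carboxylic acid, would read the same at this position.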